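Working notes: propargyl ether variant of compound 1

This account rests on a few compounds, and the source may have more. Where it says the series, first, only, none or still open, it means among the compounds named here.

Measured compounds:
compound 1 `OCCCOc1c(Br)cc(Br)cc1Oc1ccc(Br)cc1Br` gives 29.9 ug/mL
compound 2 `CC(=O)Oc1c(Br)cc(Br)cc1Oc1ccc(Br)cc1Br` gives 29.9 ug/mL
compound 3 `Brc1ccc(Oc2cc(Br)cc(Br)c2OCCCCCN2CCN(C/C=C/c3ccccc3)CC2)c(Br)c1` gives 47.2 ug/mL

All three numbers come from a functional assay on HL-60 cells (Homo sapiens) for cytotoxicity, read by MTT assay, with a stated time of 24 h; a lower number here means a stronger inhibitor, a higher number a weaker inhibitor. Compound 1 and compound 2 stand level at the digits reported, and the number for compound 3 differs from that of compound 1 by an amount within the scatter, so no order among the three can be claimed; the whole series sits in a narrow band of weak activity.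

Among the compounds with values here, the one step with a single change is no change at the digits printed from compound 1 to compound 2 (within the scatter). It removes the entire 3-hydroxypropyl, hydroxyl included, and the number does not move beyond the scatter.

Compound 4 `C#CCOc1c(Br)cc(Br)cc1Oc1ccc(Br)cc1Br` differs from compound 1 by ethynyl in place of 2-hydroxyethyl on a saturated chain carbon bound to an oxygen on an aromatic ring. Within the data shown here, this change is contained within the step from compound 1 to compound 2, which also discards the hydroxyl and the two chain carbons and shows no movement; no measured step separates the effect of the ethynyl itself. The expectation is therefore no step beyond the scatter: compound 4 is estimated at 30 ug/mL, with a range from 15 ug/mL to 60 ug/mL, corresponding to an expected step of a 1.0-fold higher number from compound 1 to compound 4 (0.00 log units; within the scatter).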

Compound 4, half-maximal inhibitory concentration: 29.7 ug/mL
Estimate against measurement, compound 4: 1.0-fold (0.00 log units) above; measured number inside the range.
By their numbers in this assay, from the lowest: compounds 4, 1, 2 and 3 (each within the scatter of the next).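

In this assay, ethynyl in place of 2-hydroxyethyl on a saturated chain carbon bound to an oxygen on an aromatic ring gives a 1.0-fold lower number from compound 1 to compound 4 (0.00 log units; within the scatter), so losing the hydroxyl while a carbon chain stays on that oxygen leaves the number within the scatter, a separation that the step from compound 1 to compound 2 could not provide. Propargyl in place of acetyl gives a 1.0-fold lower number from compound 2 to compound 4 (0.00 log units; within the scatter), so 3-hydroxypropyl, acetyl and propargyl on this oxygen cannot be told apart in this assay. Nothing available explains this flat reading.

Still open, as far as these compounds go, is whether a charged group such as a carboxylic acid or a primary amine at this oxygen would move the number beyond the scatter. Also open, from the compounds shown here alone, is whether replacing a bromine on the shared core would do so.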